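A few compounds are considered here, and "the series" means these few. Any claim that something is new, unique, unknown or untested is made for them only; others in the source may bear on it.

Measured so far in a functional assay on the whole organism with Rattus norvegicus as the target, at a dose of 1 mg/kg by the oral route; on this read-out higher numbers stand for a stronger effect at the one dose given and lower numbers for a weaker effect:
- compound 1 `COc1cc(C(=O)Nc2nn[nH]n2)nc(-c2ccc(C(C)C)cc2)c1`: 54%
- compound 2 `Cc1cc(C(=O)Nc2nn[nH]n2)nc(-c2ccc(C(C)C)cc2)c1`: 34%

Within the data shown here, compound 2 stands lowest of the two numbers in this assay; its nearest neighbour is compound 1, and the one step between them, a number 20 percentage points lower from compound 1 to compound 2 (beyond the scatter), lies beyond the scatter.

The next compound, compound 3 `CNc1ccc(-c2cc(C)cc(C(=O)Nc3nn[nH]n3)n2)cc1`, differs from compound 2 in one place: methylamino in place of isopropyl on an aromatic carbon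

Among the measured compounds shown here, no measured step bears on this change. For the measured compounds named here, the only step known, methyl in place of methoxy on an aromatic carbon, concerns a different part of the shared core and a different pair of groups, so it says nothing about replacing isopropyl with methylamino. Going by the values given here, the two measured values show only that single-point changes on this core can move the read-out by a modest amount beyond the scatter.

With no guide from the data, compound 3 is expected near the value of compound 2, with the expected step of a number 1 percentage points higher from compound 2 to compound 3 (within the scatter) carrying a wide uncertainty. The estimate for compound 3 in this assay is 35%, within a range of 10% to 65%.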

Compound 3, a percentage reported as inhibition, in the whole organism at one dose (the size of the read-out at that dose, not a potency): 89%
Compound 3: the middle estimate sits 54 percentage points below what was measured; measured number outside the range, above it.
By their numbers in this assay, from the lowest: compound 2; then compound 1; then compound 3.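

In this assay, among these compounds, the aromatic carbon para to a large group is the point of largest response seen so far on the shared core: methylamino in place of isopropyl gives a number 55 percentage points higher from compound 2 to compound 3 (beyond the scatter), whereas the only earlier step, at a different place on the core, was the modest a number 20 percentage points lower from compound 1 to compound 2 (beyond the scatter). The change exchanges isopropyl, with 3 carbon atoms and 0 hydrogen-bond donors or acceptors, for methylamino, with 2 heavy atoms, 1 hydrogen-bond donor and 1 hydrogen-bond acceptor, and this exchange raises the read-out at the one dose given rather than lowering it. No measurement at hand indicates what lies behind this rise.

Still open, from the compounds shown here alone, is whether the nitrogen or the change in heavy atoms goes with the step, a question that an unsubstituted amine, a dimethylamino group or an ethyl group at this place would help to separate. Also open, going by these compounds, is whether methylamino gives a step of similar size on the core of compound 1, which carries methoxy in place of methyl, and whether the read-out at this one dose tracks potency at all.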